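Methoxy on the Benzyl Group: Cytotoxicity Outlook for Compound 4

The source may report more compounds than this note shows. Statements on the series, on what has been measured and on what is new or still open speak of the compounds shown alone.

Three compounds have been measured in an ADME assay on HEK-293T cells (Homo sapiens) for cytotoxicity, read by CCK-8 assay, with a stated time of 24 h; a higher number here means that more compound is tolerated, a lower number that less compound is tolerated:

Compound 1, `CN(Cc1ccccc1)C(=O)CSc1c[nH]c2c(Br)cccc12`, gives 52500 nM.
Compound 2, `O=C(CSc1c[nH]c2ccccc12)NCc1ccccc1`, gives only a limit of the assay, > 100000 nM.
Compound 3, `CN(Cc1ccccc1)C(=O)CSc1c[nH]c2ccccc12`, likewise gives only a limit of the assay, > 100000 nM.

Compound 3 therefore stands at the top of what this assay can report, and it does not stand alone there: the limit of > 100000 nM in this assay, at which 2 of the 3 values shown sit. Two steps reach compound 3 from measured neighbours. The first is an at least 1.9-fold higher number from compound 1 to compound 3 (0.27 log units; that floor lies within the scatter), a change of hydrogen in place of bromo on an aromatic carbon. The second is a step that the two limits leave unreadable from compound 2 to compound 3, a change of methyl in place of hydrogen on an amide-type nitrogen.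

The unmeasured compound 4, `COc1ccccc1CN(C)C(=O)CSc1c[nH]c2ccccc12`, differs from compound 3 by methoxy in place of hydrogen on an aromatic carbon. Among the compounds with values here, none of the measured steps touches this part of the molecule, so no measured step bears directly on the change; what is known is that the shared core with the methyl amide, in compound 3, already tolerates more compound than the assay can resolve. On that basis compound 4 is expected to show no step beyond the scatter, a number no higher from compound 3 to compound 4 (the limit leaves the size open), and most likely to return another limit. Compound 4 is thus estimated at 100000 nM, within a range of 40000 nM to 200000 nM.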

Compound 4, half-maximal cytotoxic concentration: > 100000 nM
Compound 4 was reported as a limit; the forecaster's own chance of this, stated with the estimate: 70%; the middle value lies on the limit itself.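

In this assay compound 4 gives > 100000 nM, which is a limit of the assay. Compound 3 also stands at a limit, so no step can be read between compound 3 and compound 4. The compounds shown leave open whether methoxy in place of hydrogen changes the number at all, with the values crowded at one point: the limit of > 100000 nM in this assay, at which 3 of the 4 values shown sit.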